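From Difluorophenyl to Dichlorophenyl in Cell Tolerance

The source may hold more compounds than are shown below. What is called first, only, known or untested is meant among the compounds shown, and "the series" means these compounds.

Three iminosugar ethers have been tested in an ADME assay on MDBK cells (Bos taurus) for cytotoxicity, read by MTT assay; a higher number here means that more compound is tolerated, a lower number that less compound is tolerated. Compound 1 `CC1CCCC(OCCCCCCN2C[C@H](O)[C@@H](O)[C@H](O)[C@H]2CO)C1C` carries a non-aromatic ring on the ether oxygen; in this assay compound 1 gives a limit of > 500000 nM, not a number. Compound 2 `COc1ccccc1OCCCCCCN1C[C@H](O)[C@@H](O)[C@H](O)[C@H]1CO` in this assay likewise reaches only the limit > 500000 nM. Compound 3 `OC[C@@H]1[C@@H](O)[C@H](O)[C@@H](O)CN1CCCCCCOc1cc(F)ccc1F` in this assay also stops at the limit > 500000 nM. Because of the limit of > 500000 nM in this assay, at which 3 of the 3 values shown sit, none of the comparisons between them can be sized: a step that the two limits leave unreadable from compound 1 to compound 2, a step that the two limits leave unreadable from compound 1 to compound 3 and a step that the two limits leave unreadable from compound 2 to compound 3 remain unreadable. For the measured compounds named here, compound 3 therefore stands where every measured compound stands, at the limit, with no measured step separating it from the others.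

Compound 4 `OC[C@@H]1[C@@H](O)[C@H](O)[C@@H](O)CN1CCCCCCOc1cc(Cl)ccc1Cl` differs from compound 3 in one place: 2,5-dichlorophenyl in place of 2,5-difluorophenyl on an oxygen on a saturated carbon. The measured steps bear on this change only in that all three exchanges on the same oxygen left the read-out at the limit, so no step beyond the scatter is expected in this assay in either direction. Compound 4 is accordingly expected to give about 500000 nM in this assay, within an estimated range of 150000 nM to 1500000 nM, most likely again reported as a limit. The expected step is a number no higher from compound 3 to compound 4 (the limit leaves the size open).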

Compound 4, half-maximal cytotoxic concentration: 320000 nM
Compound 4: middle estimate off by 1.6-fold (0.19 log units), on the high side, within the range that was stated.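

For the compounds shown here, with 2,5-dichlorophenyl on the oxygen, compound 4 is the only one of the four compounds to give a number rather than a limit in this assay, so this position now has a read-out against which the other groups can at least be bounded. The exchange of 2,5-difluorophenyl for 2,5-dichlorophenyl gives an at least 1.5-fold lower number from compound 3 to compound 4 (0.19 log units; that floor lies within the scatter), and the two other exchanges on the same oxygen give an at least 1.5-fold lower number from compound 2 to compound 4 (0.19 log units; that floor lies within the scatter) and an at least 1.5-fold lower number from compound 1 to compound 4 (0.19 log units; that floor lies within the scatter). These figures are floors rather than sizes, and since each floor lies within the scatter they do not yet establish a real difference, because the other compound in each pair stops at a limit: the limit of > 500000 nM in this assay, at which 3 of the 4 values shown sit.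

The compounds shown leave open how large any of these three steps really is, and so whether the change to 2,5-dichlorophenyl alters tolerance in these cells at all. They also leave open whether 2,5-dibromophenyl on the same oxygen, or a longer chain between that oxygen and the shared core, would give a number in this assay that stands clear of the scatter.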